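Swapping a chloro for dimethylamino on a weak inhibitor

A few compounds are considered here, and "the series" means these few. Any claim that something is new, unique, unknown or untested is made for them only; others in the source may bear on it.

Three compounds with a shared core have been run in a functional assay, with a stated time of 10 min; on this read-out higher numbers stand for weaker inhibition and lower numbers for stronger inhibition. Compound 1 `CCOC(=O)c1cnn(-c2nc(-c3ccc(Cl)cc3)c(C#N)c(=O)n2C)c1N` gives 94 ug/mL, the highest of the three numbers. Compound 2 `CN(C)c1ccc(-c2nc(NN)n(C)c(=O)c2C#N)cc1`, which also carries a 4-(dimethylamino)phenyl group, gives 66 ug/mL, a value within the usual scatter of that of compound 1, so no order between these two can be claimed. Compound 3 `COc1cccc(-c2nc(SC)n(C)c(=O)c2C#N)c1OC` gives 43 ug/mL, a number lower than that of compound 1 by more than the scatter, so compound 3 is the stronger inhibitor of that pair.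

For the measured compounds named here, the next compound, compound 4 `CCOC(=O)c1cnn(-c2nc(-c3ccc(N(C)C)cc3)c(C#N)c(=O)n2C)c1N`, keeps the whole framework of compound 1 and changes only one group: dimethylamino in place of chloro on an aromatic carbon. Going by the values given here, no pair of measured compounds differs in this one place alone, so the size of this step has to be guessed from the spread of the three values, which all lie within a narrow band on this assay. The expected step in this assay is therefore small, toward slightly stronger inhibition at most, and is likely to stay within the scatter: a 1.3-fold lower number from compound 1 to compound 4 (0.10 log units; within the scatter). On that basis compound 4 is expected to give about 75 ug/mL, with a range from 35 ug/mL to 160 ug/mL.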

Compound 4, half-maximal inhibitory concentration: 119 ug/mL
For compound 4 the middle estimate is 1.6-fold (0.20 log units) below the measured one; low and high end bracket the measured number.
By their numbers in this assay, from the lowest: compounds 3, 2, 1 and 4 (each within the scatter of the next, the first and the last beyond it).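

In this assay, for the compounds shown here, this position can now be read directly for the first time, and the exchange gives a 1.3-fold higher number from compound 1 to compound 4 (0.10 log units; within the scatter). Within the scatter of the assay, then, the 4-chlorophenyl and 4-(dimethylamino)phenyl compounds cannot be told apart, even though a single chlorine atom is replaced by a group of three heavy atoms that adds a hydrogen-bond acceptor. No measurement at hand bears on why these two groups read alike, and the data offer no explanation for this result.

A single pair of groups says little about the position as a whole, so a hydroxyl group, a carboxylic acid or a longer chain such as butoxy on this aromatic carbon might either move the number beyond the scatter or leave it within it. From the compounds shown here alone, it also remains open whether the same exchange of chloro for dimethylamino would read the same way on a framework other than that of compound 1, such as the ones carried by compound 2 and compound 3.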